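A few compounds are considered here, and "the series" means these few. Any claim that something is new, unique, unknown or untested is made for them only; others in the source may bear on it.

Compound 1 (`COC(=O)c1c[nH]c2cc(OCCOc3ccccc3)ccc2c1=O`), compound 2 (`COC(=O)c1c[nH]c2cc(OCCOc3ccccc3)c(OC)cc2c1=O`) and compound 3 (`CCc1cc2c(=O)c(C(=O)OC)c[nH]c2cc1OCCOc1ccccc1`) share one core. In an ADME assay on J774 cells (Mus musculus) for cytotoxicity (on this read-out higher numbers stand for an effect only at larger amounts of compound and lower numbers for an effect already at smaller amounts), compound 1 gives > 20000 nM as a limit, not a number. Compound 2 gives > 20000 nM as a limit too. Compound 3 gives > 20000 nM as a limit as well, so it has no exact position. Every reading so far is the limit of > 20000 nM in this assay, at which 3 of the 3 values shown sit, and nothing more. Among the compounds with values here, compound 4 (`COC(=O)c1c[nH]c2cc(OCCOc3ccccc3)c(Br)cc2c1=O`) carries bromo in place of ethyl on an aromatic carbon as its only change. Within the data shown here, three measured steps bear on this: a step that the two limits leave unreadable from compound 1 to compound 2 and a step that the two limits leave unreadable from compound 1 to compound 3 and a step that the two limits leave unreadable from compound 2 to compound 3 alike. None has a readable size, so no shift in either direction is expected in this assay beyond the scatter. The expected step is a step that the limit leaves unreadable from compound 3 to compound 4 at most a small one. For compound 4 the estimate is 25000 nM with an expected range from 12000 nM to 50000 nM in this read-out.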

Compound 4, half-maximal effective concentration: > 20000 nM
Compound 4: a limit, no number; the forecaster's own chance of this, stated with the estimate: 85%; the middle value does not contradict the limit.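

Compound 4 gives only a limit, just like compound 1, compound 2 and compound 3, so no step involving compound 4 can be read: the limit of > 20000 nM in this assay, at which 4 of the 4 values shown sit.

The compounds shown leave open where each would take effect in this assay, and whether hydrogen, methoxy, ethyl and bromo differ there at all.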